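A 2,4-difluorophenyl group on a sulfonamide nitrogen

This account rests on a few compounds, and the source may have more. Where it says the series, first, only, none or still open, it means among the compounds named here.

In a physicochemical assay for lipophilicity, at pH 7.4 (on this read-out higher numbers stand for higher lipophilicity and lower numbers for lower lipophilicity), compound 2 (`CC(C)CN(C1CCc2ccc(F)cc21)S(=O)(=O)c1ccc2c(c1)C(O)CC(C1CCOCC1)O2`) gives 3.94 as the higher of the two measured numbers, and compound 1 (`CC(C)CN(c1ccccc1F)S(=O)(=O)c1ccc2c(c1)C(O)CC(C1CCOCC1)O2`) gives 3.39 as the lower. Within the data shown here, the only measured step, a modest one, is a number 0.55 log units higher from compound 1 to compound 2 (beyond the scatter) and lies beyond the scatter.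

Compound 3 (`CC(C)CN(c1ccc(F)cc1F)S(=O)(=O)c1ccc2c(c1)C(O)CC(C1CCOCC1)O2`) has not yet been measured. Its difference from compound 2 is 2,4-difluorophenyl in place of 6-fluoro-2,3-dihydro-1H-inden-1-yl on a sulfonamide nitrogen and amounts to 2,4-difluorophenyl in place of 6-fluoro-2,3-dihydro-1H-inden-1-yl on a sulfonamide nitrogen. The measured step bears on this change only when read in reverse, since compound 1 carries 2-fluorophenyl at that place. Among the measured compounds shown here, it is not an exact reversal, and no measured compound shows 2,4-difluorophenyl itself. The expectation therefore rests on compound 1 at 3.39 as the closest measured comparison. The step is expected to run downward, with a number 0.39 log units lower from compound 2 to compound 3 (beyond the scatter) as the estimate, slightly smaller than the measured one. The expected value for compound 3 is 3.55 with 3.25 to 3.85 as the estimated range.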

Compound 3, distribution coefficient: 3.53
Beside the measured number, compound 3's estimate is 0.02 log units above it; low and high end bracket the measured number.
By their numbers in this assay, from the lowest: compounds 1 and 3 (each within the scatter of the next); then compound 2.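

In this assay, fluoro in place of hydrogen on an aromatic carbon gives a number 0.14 log units higher from compound 1 to compound 3 (within the scatter), so the added fluoro on the phenyl ring does not separate compound 3 from compound 1 in this read-out. With 2,4-difluorophenyl in place of 6-fluoro-2,3-dihydro-1H-inden-1-yl on the sulfonamide nitrogen, the result is a number 0.41 log units lower from compound 2 to compound 3 (beyond the scatter), and among these three compounds, both fluorophenyl compounds give lower numbers than the one carrying the 6-fluoro-2,3-dihydro-1H-inden-1-yl group, with none going against this. No measurement accompanies these numbers that could explain the difference between the groups.

Still open, going by these compounds, is how a plain phenyl, a pyridyl or a cyclohexyl group on the sulfonamide nitrogen would read in this assay, and whether a 2,3-dihydro-1H-inden-1-yl group without its fluoro would stay close to compound 2. On these data alone, it is equally open whether the gap between these groups would persist with a longer chain or a chain ending in an amine on the same nitrogen, since all three compounds share one chain there.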